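This account rests on a few compounds, and the source may have more. Where it says the series, first, only, none or still open, it means among the compounds named here.

Measured so far:
compound 1 `CCc1ccc(NS(=O)(=O)c2ccc(N3CCNC3=O)cc2)cc1` — 480 nM
compound 2 `CCCCOc1ccc(NS(=O)(=O)c2ccc(N3CCNC3=O)cc2)cc1` — 580 nM
compound 3 `O=C1NCCN1c1ccc(S(=O)(=O)Nc2ccc(Br)cc2)cc1` — 130 nM

In a functional assay on M21 cells (Homo sapiens) for antiproliferative activity, read by sulforhodamine B assay, with a stated time of 48 h (a higher number here means a weaker inhibitor, a lower number a stronger inhibitor), compound 3 gives the lowest of the three numbers; the nearest is compound 1, and the gap a 3.7-fold lower number from compound 1 to compound 3 (0.57 log units; beyond the scatter) lies beyond the scatter, as does a 4.5-fold lower number from compound 2 to compound 3 (0.65 log units; beyond the scatter). Compound 4 `CC(C)(C)c1ccc(NS(=O)(=O)c2ccc(N3CCNC3=O)cc2)cc1` differs from compound 3 as follows: tert-butyl in place of bromo on an aromatic carbon. Two steps bear on this one: replacing bromo by ethyl or by butoxy each gave a higher number, shown by a 3.7-fold lower number from compound 1 to compound 3 (0.57 log units; beyond the scatter) and a 4.5-fold lower number from compound 2 to compound 3 (0.65 log units; beyond the scatter) read in reverse, while a 1.2-fold higher number from compound 1 to compound 2 (0.08 log units; within the scatter) shows the two carbon substituents close to each other. A tert-butyl in place of bromo is therefore expected to move the number upward by a modest amount, a 3.1-fold higher number from compound 3 to compound 4 (0.49 log units; beyond the scatter). For compound 4 the estimate in this assay is 400 nM, with a range of 150 nM to 1200 nM.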

Compound 4, half-maximal inhibitory concentration: > 1000 nM
Compound 4: a limit, no number; the forecaster's own chance of this, stated with the estimate: 3%; at least 2.5-fold (0.39 log units) between middle value and limit.
By their numbers in this assay, from the lowest: compound 3; then compounds 1 and 2 (each within the scatter of the next). At a limit, above all of these: compound 4.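

In this assay compound 4 stands at a limit and not a number: the limit of > 1000 nM in this assay, at which 1 of the 4 values shown sits. Replacing bromo gives an at least 7.6-fold higher number from compound 3 to compound 4 (0.88 log units; beyond the scatter), and replacing ethyl gives an at least 2.0-fold higher number from compound 1 to compound 4 (0.31 log units; beyond the scatter), so this position separates tert-butyl from ethyl, whereas the earlier ethyl and butoxy pair showed no such separation. Against butoxy the step is an at least 1.7-fold higher number from compound 2 to compound 4 (0.23 log units; that floor lies within the scatter), so no order can be set there.

Still open, as far as these compounds go, is how far the true value of compound 4 lies past its limit. Also open, from the compounds shown here alone, is whether chloro, an amine or a carboxylic acid on this aromatic carbon would match bromo.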